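Swapping a hydroxyl-ended chain for a methoxy-ended one

A few compounds are considered here, and "the series" means these few. Any claim that something is new, unique, unknown or untested is made for them only; others in the source may bear on it.

Compound 1 `O=C(/C=C(/C=C/c1ccc(O)cc1)NCCCO)/C=C/c1ccc(O)cc1` and compound 3 `COCCNC(=C\C(=O)/C=C/c1ccc(O)cc1)/C=C/c1ccc(O)cc1` share one core and differ only in the chain on the amine nitrogen. In a toxicity assay on CHO-K1 cells (Cricetulus griseus) for cytotoxicity, read by MTT assay, with a stated time of 48 h (a higher number here means a weaker inhibitor, a lower number a stronger inhibitor), compound 1 gives 39100 nM, and compound 3 gives 34900 nM. The change between them is methoxy in place of hydroxymethyl on a saturated chain carbon, two bonds along the chain from an amine nitrogen, and it made a step of a 1.1-fold lower number from compound 1 to compound 3 (0.05 log units; within the scatter).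

Compound 2 `COc1cc(/C=C/C(=O)/C=C(/C=C/c2ccc(O)c(OC)c2)NCCCO)ccc1O` has a different core; how its core differs from that of compound 1 is not broken down here. In this assay compound 2 gives 88500 nM, the highest of the three numbers, beyond the scatter from both compound 1 and compound 3.

Compound 4 `COCCNC(=C\C(=O)/C=C/c1ccc(O)c(OC)c1)/C=C/c1ccc(O)c(OC)c1` is not yet measured. It stands to compound 2 as compound 3 stands to compound 1: the change is methoxy in place of hydroxymethyl on a saturated chain carbon, two bonds along the chain from an amine nitrogen, the same change at the same place. Because a 1.1-fold lower number from compound 1 to compound 3 (0.05 log units; within the scatter) was within the scatter, the step from compound 2 to compound 4 is expected to be small as well, about a 1.1-fold lower number from compound 2 to compound 4 (0.04 log units; within the scatter). Compound 4 is therefore expected to give about 80000 nM, most likely between 40000 nM and 160000 nM.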

Compound 4, half-maximal inhibitory concentration: 63000 nM
For compound 4 the middle estimate is 1.3-fold (0.10 log units) above the measured one; measured number inside the range.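

In this assay the new step is a 1.4-fold lower number from compound 2 to compound 4 (0.15 log units; within the scatter), so putting methoxy in place of hydroxymethyl at this place on the chain again gives a step that cannot be told from the usual scatter. Set side by side, the steps on the two cores agree as closely as repeated measurements would be expected to: the same change on two cores in this assay, a 1.1-fold lower number (0.05 log units; within the scatter) from compound 1 to compound 3 and a 1.4-fold lower number (0.15 log units; within the scatter) from compound 2 to compound 4, 1.3-fold (0.10 log units) apart, within the scatter of two such steps. This shows that, for these two pairs in this one cell toxicity test, the change carried over from one core to the other without a visible step, but it does not show that the change would be equally small on other cores or in other tests, and two pairs cannot establish a general rule.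

The only chains shown are 3-hydroxypropyl and 2-methoxyethyl, which leaves open what a different group at this place, such as an amine, a carboxylic acid or a longer chain, would do to the number. Going by these compounds, it also remains open whether any such group would give a step beyond the scatter on either core.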